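Adding an Amino Group on Two Differently Joined Cores

The source may report more compounds than this note shows. Statements on the series, on what has been measured and on what is new or still open speak of the compounds shown alone.

Compound 1 `ClCc1ccc(Cn2cnc3c(Cl)ncnc32)cc1` gives 51300 nM in a functional assay on A549 cells (Homo sapiens) for cytotoxicity, read by sulforhodamine B assay, with a stated time of 48 h; on this read-out higher numbers stand for lower toxicity in this test and lower numbers for higher toxicity in this test.
Compound 2 `Nc1nc(Cl)c2ncn(Cc3ccc(CCl)cc3)c2n1` reaches only a limit of this assay, > 100000 nM.
Compound 3 `ClCc1ccccc1Cn1cnc2c(Cl)ncnc21` gives 75900 nM in this assay.

Compounds 1 and 3 share the same atoms joined differently; the difference between the two cores is not broken down here. Compound 2 differs from compound 1 by amino in place of hydrogen on an aromatic carbon, and the result was an at least 1.9-fold higher number from compound 1 to compound 2 (0.28 log units; that floor lies within the scatter), a floor set by the limit of > 100000 nM in this assay, at which 1 of the 3 values shown sits, rather than a number. Compound 3 and compound 1 sit within the usual scatter of each other in this assay.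

Compound 4 `Nc1nc(Cl)c2ncn(Cc3ccccc3CCl)c2n1` has not yet been measured. It differs from compound 3 by amino in place of hydrogen on an aromatic carbon, the same change that was made from compound 1 to compound 2. Because compound 2 only reached the limit > 100000 nM, the step to compound 4 is expected to be of similar size, roughly a 2.0-fold higher number from compound 3 to compound 4 (0.30 log units; within the scatter), with a fair chance that compound 4 also reports only a limit. Compound 4 is therefore estimated at 150000 nM, plausibly between 70000 nM and 400000 nM.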

Compound 4, concentration lethal to 50% of the cells: > 100000 nM
Compound 4 gave a limit, no number (the forecaster's own chance of this, stated with the estimate: 60%); the middle value lies beyond the limit too.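

In this assay compound 4 reports only a limit, > 100000 nM, and not a number. Amino in place of hydrogen on an aromatic carbon gives an at least 1.3-fold higher number from compound 3 to compound 4 (0.11 log units; that floor lies within the scatter), so on this second core, as on the first, the change leaves only a floor and no measured size. The two cores therefore end alike at the limit, but this does not show that the change raises the number on either core, nor that its size carries over from one core to the other: the same change on two cores in this assay, an at least 1.9-fold higher number (0.28 log units; that floor lies within the scatter) from compound 1 to compound 2 and an at least 1.3-fold higher number (0.11 log units; that floor lies within the scatter) from compound 3 to compound 4; the limit leaves it open whether they differ.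

The compounds shown leave open the actual values of compound 2 and compound 4, which stand only as limits: the limit of > 100000 nM in this assay, at which 2 of the 4 values shown sit. They also leave open whether a methylamino group, a hydroxyl group or a methoxy group on that same aromatic carbon would give a number on either core in this assay.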